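The source may report more compounds than this note shows. Statements on the series, on what has been measured and on what is new or still open speak of the compounds shown alone.

Compound 1 `Fc1cccc(-c2nc(Nc3ccccc3)c3cc(F)ccc3n2)c1`: in a functional assay on MCF7 cells (Homo sapiens) for cytotoxicity, read by MTT assay, with a stated time of 48 h (a lower number here means a stronger inhibitor, a higher number a weaker inhibitor), compound 1 gives 49700 nM.
Compound 2 `Fc1cccc(-c2nc(Nc3cccc(Cl)c3)c3cc(F)ccc3n2)c1`: compound 2 gives > 50000 nM, which is a limit of the assay rather than a number.
Compound 3 `Fc1cccc(-c2nc(Nc3cccc(Br)c3)c3cc(F)ccc3n2)c1`: compound 3 gives > 50000 nM, again a limit of the assay.

Compound 3 therefore stands at the edge of what this assay can report, and it is not alone there: the limit of > 50000 nM in this assay, at which 2 of the 3 values shown sit. Compound 4 `Oc1cccc(Nc2nc(-c3cccc(F)c3)nc3ccc(F)cc23)c1` differs from compound 3 in one place: hydroxy in place of bromo on an aromatic carbon.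

Among the measured compounds shown here, three measured steps bear on this position. The step of a number no lower from compound 1 to compound 2 (the limit leaves the size open) and the step of a number no lower from compound 1 to compound 3 (the limit leaves the size open) both show that adding a halogen there did not make the compound stronger, while the step that the two limits leave unreadable from compound 2 to compound 3 cannot be read at all. For the measured compounds named here, no step within the set shows a change beyond the scatter, and nothing here shows what a hydroxy at that position does.

The step of an at least 1.1-fold lower number from compound 3 to compound 4 (0.04 log units; that floor lies within the scatter) is expected to stay within the scatter. Compound 4 is accordingly estimated at 45000 nM, with a range from 15000 nM to 150000 nM, and a real chance of another limit.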

Compound 4, half-maximal inhibitory concentration: > 50000 nM
Compound 4 was reported as a limit; the forecaster's own chance of this, stated with the estimate: 55%; middle value at least 1.1-fold (0.04 log units) away from the limit.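

In this assay compound 4 gives > 50000 nM, which is a limit of the assay and not a number. The step of a number no lower from compound 1 to compound 4 (the limit leaves the size open) shows that hydroxy in place of hydrogen did not make the compound stronger, so a group carrying a hydrogen-bond donor fares no better here than chloro or bromo, something the halogens alone could not show. The steps from compound 2 and compound 3 to compound 4 cannot be read, and the three substituted compounds cannot be ranked against one another: the limit of > 50000 nM in this assay, at which 3 of the 4 values shown sit.

Going by these compounds, what an amine or a carboxylic acid would do on an aromatic carbon at this place stays open. Also open, on these data alone, is whether a change elsewhere on the shared core would give a clearly lower number than compound 1 shows at 49700 nM.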